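The source may report more compounds than this note shows. Statements on the series, on what has been measured and on what is new or still open speak of the compounds shown alone.

Measured compounds so far:
- compound 1, `CC(C(=O)NCc1ccc(C(F)(F)F)cc1OCc1ccccc1)c1ccc(NS(C)(=O)=O)c(F)c1`, gives 0.9 nM in an assay on CHO cells for antagonist activity at transient receptor potential cation channel subfamily V member 1 (Homo sapiens), read by FLIPR; a lower number here means a stronger inhibitor, a higher number a weaker inhibitor
- compound 2, `C[C@@H](C(=O)NCc1ccc(C(F)(F)F)cc1SC1CCCCC1)c1ccc(NS(C)(=O)=O)c(F)c1`, gives 13.9 nM in this assay
- compound 3, `C[C@H](C(=O)NCc1ccc(C(F)(F)F)cc1SC1CCCCC1)c1ccc(NS(C)(=O)=O)c(F)c1`, gives 0.3 nM in this assay

Compound 1 holds the middle position of the three: compound 3 lies below it and compound 2 above it, and both gaps are beyond the scatter, the gap to compound 2 being the wider one. For the measured compounds named here, the one step between compounds that differ in a single place is a 46-fold lower number from compound 2 to compound 3 (1.67 log units; beyond the scatter), and it rests on (the fact that compounds 2 and 3 differ only in the configuration as drawn). Compound 1 carries no drawn configuration at the chain carbon, so its number spans whatever the two configurations contribute.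

Compound 4, `COc1ccc(-c2cc(C(F)(F)F)ccc2CNC(=O)C(C)c2ccc(NS(C)(=O)=O)c(F)c2)cc1OC`, is reached from compound 1 by one change: 3,4-dimethoxyphenyl in place of benzyloxy on an aromatic carbon. Going by the values given here, no measured step concerns this position or either of these groups, and the stereochemical step between compound 2 and compound 3 gives no guidance on a change at the aromatic carbon. The expectation for this assay therefore rests on compound 1 alone, with a step of uncertain direction and most likely modest size. Compound 4 is expected to give about 3 nM, within 0.5 nM to 20 nM. This estimate corresponds to a step of a 3.3-fold higher number from compound 1 to compound 4 (0.52 log units; beyond the scatter).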

Compound 4, inhibition constant: 8.6 nM
Compound 4: middle estimate off by 2.9-fold (0.46 log units), on the low side, within the range that was stated.
By their numbers in this assay, from the lowest: compound 3; then compound 1; then compounds 4 and 2 (each within the scatter of the next).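

Until now, nothing showed how this position responds to the group it carries; a change on this aromatic carbon, meta to a trifluoromethyl group, now registers in this assay as a step beyond the scatter. Replacing benzyloxy with 3,4-dimethoxyphenyl gives a 9.6-fold higher number from compound 1 to compound 4 (0.98 log units; beyond the scatter), so the position distinguishes between these two groups, although compound 4 still gives 8.6 nM. The available evidence concerns only a difference in drawn configuration and offers no explanation for this change at the aromatic carbon.

For the compounds shown here, the single step changes the group's attachment and its substitution together, leaving open whether the higher number belongs to the loss of the oxygen and methylene link or to the two methoxy groups; an unsubstituted phenyl, a phenoxy group or a 4-methoxyphenyl group at this position would help separate those contributions. Going by these compounds alone, also open are how an amine such as morpholine or a carboxylic acid on the added ring would read in this assay, and whether the single configurations of compound 1 and compound 4 would separate as widely as the pair already measured.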